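Lengthening the ether chain of compound 2

This account rests on a few compounds, and the source may have more. Where it says the series, first, only, none or still open, it means among the compounds named here.

In a functional assay on MES-SA/Dx5 cells (Homo sapiens) for inhibition, with a stated time of 72 h (on this read-out higher numbers stand for weaker inhibition and lower numbers for stronger inhibition), compound 1 `COCc1cc(CN2CCCC2)c(O)c2ncccc12` reads 1350 nM and compound 2 `COCc1cc(CN2CCCCC2)c(O)c2ncccc12` reads 912 nM (the two lie within the scatter of each other), so compound 2 is not set apart from compound 1. Compound 3 `CCCOCc1cc(CN2CCCCC2)c(O)c2ncccc12` turns methoxymethyl into propoxymethyl ethyl in place of hydrogen on a saturated chain carbon bound to an oxygen on a saturated carbon and keeps the rest of compound 2. Among the measured compounds shown here, the one measured step of a 1.5-fold lower number from compound 1 to compound 2 (0.17 log units; within the scatter) lies within the scatter and concerns a different group, piperidin-1-yl in place of pyrrolidin-1-yl, so it gives no direct guide to this chain. Only a step within the scatter is therefore expected in this assay (estimated as a 1.1-fold lower number from compound 2 to compound 3 (0.06 log units; within the scatter)) in no firm direction. Compound 3 is expected at 800 nM (estimated range 300 nM to 2100 nM).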

Compound 3, half-maximal inhibitory concentration: 339 nM
Compound 3: middle estimate off by 2.4-fold (0.37 log units), on the high side; low and high end bracket the measured number.
By their numbers in this assay, from the lowest: compound 3; then compounds 2 and 1 (each within the scatter of the next).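

Going from methoxymethyl to propoxymethyl in this assay gives a 2.7-fold lower number from compound 2 to compound 3 (0.43 log units; beyond the scatter) and so counts as a modest step. This shows that the ether chain can move the number beyond the scatter, which the earlier change from pyrrolidin-1-yl to piperidin-1-yl did not show. Nothing available accounts for this step.

From the compounds shown here alone, whether a longer chain such as butoxymethyl would continue this trend, or how a branched isopropoxymethyl or an amine on the chain would read, stays open. Going by these compounds, it is equally open whether propoxymethyl has the same effect alongside pyrrolidin-1-yl.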